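Plasma stability of carbapenem ester series

A few compounds are considered here, and "the series" means these few. Any claim that something is new, unique, unknown or untested is made for them only; others in the source may bear on it.

Working notes on a small set of esters sharing one core. Compound 1 `C[C@@H](O)[C@H]1C(=O)N2C3=C(S[C@@H]4CN[C@@H](C4)C(=O)Nc4cccc(c4)C(=O)OCc4oc(=O)oc4COC3=O)[C@H](C)[C@H]12` is the cyclic ester of the series; in an ADME assay on a cell-free system (plasma, Homo sapiens) for metabolic stability, read by LC-MS, with a stated time of 60 min, at 37 degrees C, tested at 50 uM (a lower number here means that less of the compound is left, a higher number that more of the compound is left), compound 1 gives 0%. Compound 3 `C[C@@H](O)[C@H]1C(=O)N2C(C(=O)OCC(F)(F)F)=C(S[C@@H]3CN[C@H](C(=O)Nc4cccc(C(=O)OCC(F)(F)F)c4)C3)[C@H](C)[C@H]12` carries two trifluoroethyl esters, and in this assay compound 3 gives 6%. Both numbers sit at the low end of the read-out, so nearly all of each compound is gone over the test period.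

Compound 2 `C[C@@H](O)[C@H]1C(=O)N2C(C(=O)O)=C(S[C@@H]3CN[C@H](C(=O)Nc4cccc(C(=O)OCC(F)(F)F)c4)C3)[C@H](C)[C@H]12` carries the free acid on the core and a single trifluoroethyl ester on the side chain. In this assay compound 2 is recorded as "not determined" (no result reported), so it has no number to stand on, and no direction or size of step to compound 4 can be given from the data.

Compound 4 `C[C@@H](O)[C@H]1C(=O)N2C(C(=O)O)=C(S[C@@H]3CN[C@H](C(=O)Nc4cccc(C(=O)OCOC(=O)C(C)(C)C)c4)C3)[C@H](C)[C@H]12` differs from compound 2 in one place: ((tert-butyl)carbonyl)oxy in place of trifluoromethyl on a saturated chain carbon bound to an oxygen next to a carbonyl group. The change replaces the trifluoroethyl ester with an acyloxymethyl ester while the free acid on the core is kept.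

As compound 2 has no number, the expectation for compound 4 rests on compound 1 with 0% and on compound 3 with 6%, both of which show little compound remaining. Compound 4 is therefore expected to give about 5% in this assay, within a range of 0% to 25%.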

Compound 4, percent of the compound remaining: 53%
Estimate against measurement, compound 4: 48 percentage points below; measured number above the stated range.
By their numbers in this assay, from the lowest: compounds 1 and 3 (each within the scatter of the next); then compound 4.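

No new step can be read: compound 2 has no number, so the change from compound 2 to compound 4 cannot be sized. The compounds shown leave open whether going from 2,2,2-trifluoroethyl to (((tert-butyl)carbonyl)oxy)methyl alters how much compound remains. No measured evidence bears on this result.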